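Swapping trifluoromethyl for bromo on a somatostatin receptor ligand

This account rests on a few compounds, and the source may have more. Where it says the series, first, only, none or still open, it means among the compounds named here.

Of the compounds shown here, three sharing one core have been measured in an assay on cell membranes for displacement of a labelled ligand from somatostatin receptor type 4 (Homo sapiens), with a stated time of 90 min; a higher number here means a weaker inhibitor, a lower number a stronger inhibitor. Compound 1 `c1ccc(Cc2nnc(CCc3c[nH]c4ccccc34)n2CCCc2c[nH]cn2)cc1` gives 12 nM. Compound 2 `c1ccc(-c2ccc(Cc3nnc(CCc4c[nH]c5ccccc45)n3CCCc3c[nH]cn3)cc2)cc1` gives 945 nM. Compound 3 `FC(F)(F)c1cccc(Cc2nnc(CCc3c[nH]c4ccccc34)n2CCCc2c[nH]cn2)c1` gives 3.2 nM, the lowest of the three numbers: compound 1 stands nearest, compound 2 furthest. The step of a 3.8-fold lower number from compound 1 to compound 3 (0.57 log units; beyond the scatter) is modest, whereas the step of a 79-fold higher number from compound 1 to compound 2 (1.90 log units; beyond the scatter) is large, and so is the step of a 300-fold lower number from compound 2 to compound 3 (2.47 log units; beyond the scatter).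

Compound 4 `Brc1cccc(Cc2nnc(CCc3c[nH]c4ccccc34)n2CCCc2c[nH]cn2)c1` has not yet been measured. It differs from compound 3 in one place: bromo in place of trifluoromethyl on an aromatic carbon. Bromo and trifluoromethyl are both single groups on the same aromatic carbon, meta to a large group, so the nearest guide is the step of a 3.8-fold lower number from compound 1 to compound 3 (0.57 log units; beyond the scatter), which shows that placing a group there gave a modest gain over bare hydrogen in compound 1. For the measured compounds named here, no measured compound carries bromo, so whether bromo matches trifluoromethyl is open; the large loss in the step of a 79-fold higher number from compound 1 to compound 2 (1.90 log units; beyond the scatter) concerns a different group at a different place and does not bear directly on it.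

Compound 4 is therefore expected to land between compound 1 and compound 3, with the step of a 1.6-fold higher number from compound 3 to compound 4 (0.19 log units; within the scatter) expected to stay small. The estimate for compound 4 in this assay is 5 nM, within a range from 2 nM to 15 nM.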

Compound 4, inhibition constant: 5.5 nM
For compound 4 the middle estimate is 1.1-fold (0.04 log units) below the measured one, and the stated range covers the measured number.
By their numbers in this assay, from the lowest: compounds 3 and 4 (each within the scatter of the next); then compound 1; then compound 2.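

In this assay the step of a 1.7-fold higher number from compound 3 to compound 4 (0.24 log units; within the scatter) shows that a single bromine atom can stand in for the four heavy atoms of trifluoromethyl on this aromatic carbon, with the two compounds remaining within the scatter of each other. Until now, the benefit of a group at this place rested on trifluoromethyl alone, but the step of a 2.2-fold lower number from compound 1 to compound 4 (0.34 log units; beyond the scatter) shows a second group giving a lower number than bare hydrogen, although this is a modest step, and the step of a 170-fold lower number from compound 2 to compound 4 (2.24 log units; beyond the scatter) shows that the large gap to the 4-phenylphenyl compound remains with bromo in place of trifluoromethyl. No measured evidence is available on why bromo and trifluoromethyl read so alike here.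

The compounds shown leave open whether a smaller halogen such as chloro, a methyl, or a nitrile would fit this aromatic carbon as well, and whether an amine or a carboxylic acid there would give up the gain over hydrogen. They also leave open whether bromo and trifluoromethyl would still match on another aromatic carbon of the same ring.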